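From Isobutoxy to Allyloxy: Estimating Compound 4

The source may hold more compounds than are shown below. What is called first, only, known or untested is meant among the compounds shown, and "the series" means these compounds.

The measured compounds:
compound 1, `CC(C)COc1ccc2c(Cl)ccnc2c1`, gives 2680 nM in a functional assay on RKO cells (Homo sapiens) for cytotoxicity, read by MTT assay, with a stated time of 48 h; a lower number here means a stronger inhibitor, a higher number a weaker inhibitor
compound 2, `CCOc1ccc2c(NCCN(C)C)ccnc2c1`, gives 3650 nM in this assay
compound 3, `CCOc1ccc2c(NCCCN(C)C)ccnc2c1`, gives 5240 nM in this assay

Among the three, compound 1 has the lowest number, but its gaps to compound 2 and to compound 3 are both within the scatter, so no order among them can be claimed. Going by the values given here, the only step joining two measured compounds, a 1.4-fold higher number from compound 2 to compound 3 (0.16 log units; within the scatter), concerns the amine-bearing chain rather than the alkoxy group, and it too stays within the scatter. Compound 4, `C=CCOc1ccc2c(Cl)ccnc2c1`, differs from compound 1 by vinyl in place of isopropyl on a saturated chain carbon bound to an oxygen on an aromatic ring. Among the compounds with values here, no measured step touches the alkoxy group, so the measured steps offer no direct guide; what they do show is that all three numbers sit close together whatever the substituent. It is therefore expected that the step in this assay from compound 1 to compound 4 is a 1.0-fold higher number from compound 1 to compound 4 (0.00 log units; within the scatter), not beyond the scatter. Compound 4 is estimated at 2700 nM, with a range from 1300 nM to 5600 nM.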

Compound 4, half-maximal inhibitory concentration: 2460 nM
For compound 4 the middle estimate is 1.1-fold (0.04 log units) above the measured one; the measured number falls inside the stated range.
By their numbers in this assay, from the lowest: compounds 4, 1, 2 and 3 (each within the scatter of the next, the first and the last beyond it).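

Going by these compounds alone, the step from isobutoxy to allyloxy is the first measured change at this position, and in this assay it stays within the scatter (a 1.1-fold lower number from compound 1 to compound 4 (0.04 log units; within the scatter)). Vinyl in place of isopropyl on a saturated chain carbon bound to an oxygen on an aromatic ring, which swaps a group of 3 heavy atoms for one of 2 and adds a double bond outside aromatic rings, thus gives no readable change in this cytotoxicity read-out on the core of compound 1. Nothing available explains why the two numbers stay so close.

On these data alone, it remains open whether a carboxylic acid, an amine, a phenyl ring or a much longer chain at this place would move the number beyond the scatter. As far as these compounds go, it is equally open whether the isobutyl to allyl change would behave the same way on a core carrying the dimethylamino chains of compound 2 and compound 3.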